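Thiazole to Isoxazole at the Amide Methylene: Expected Half-Life

This account rests on a few compounds, and the source may have more. Where it says the series, first, only, none or still open, it means among the compounds named here.

Measured so far:
compound 1, `CCCC[C@H](NC(=O)OC(C(C)C)C(C)C)C(=O)C(=O)NCc1cncs1`: 2.5 h
compound 2, `CNC(=O)NCCCC[C@H](NC(=O)OC(C(C)C)C(C)C)C(=O)C(=O)N[C@H](C)c1ccccc1`: 4.33 h

Both values come from an in vivo ADME assay on the whole organism for pharmacokinetics, with Rattus norvegicus as the target; on this read-out lower numbers stand for a shorter-lived compound and higher numbers for a longer-lived compound. Compound 1 gives 2.5 h in this assay, and compound 2 gives 4.33 h. The two numbers lie within the scatter of each other, so compound 1 stands within the scatter of compound 2 and neither can be told apart from the other on these data. Among the measured compounds shown here, compound 2 also differs from compound 1 in more than one place, so no single step between measured compounds is available.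

The unmeasured compound is compound 3, `CCCC[C@H](NC(=O)OC(C(C)C)C(C)C)C(=O)C(=O)NCc1ccno1`. It differs from compound 1 by a single change: 1,2-oxazol-5-yl in place of 1,3-thiazol-5-yl on a saturated chain carbon bound to an amide-type nitrogen. For the measured compounds named here, no measured pair shows this change, and the rest of the structure of compound 1 is kept.

Going by the values given here, with nothing among the measured compounds to point either way, compound 3 is expected to stay close to compound 1, and the step of no change at the digits printed from compound 1 to compound 3 (within the scatter) is expected to be none beyond the scatter. Compound 3 is estimated at 2.5 h in this assay, within the range 1.2 h to 5 h.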

Compound 3, half-life in the Rattus norvegicus assay: 0.867 h
Compound 3: the middle estimate sits 2.9-fold (0.46 log units) above what was measured, and the stated range ends above it.
By their numbers in the Rattus norvegicus assay, from the lowest: compound 3; then compounds 1 and 2 (each within the scatter of the next).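

Among the compounds shown here, in the Rattus norvegicus assay, putting 1,2-oxazol-5-yl in place of 1,3-thiazol-5-yl on a saturated chain carbon bound to an amide-type nitrogen gives a 2.9-fold lower number from compound 1 to compound 3 (0.46 log units; beyond the scatter), the first step in this set that can be read at a single place, and it shows that the half-life at this position depends on which of these two rings is present, although both have 5 heavy atoms and the same counts of donors and acceptors. In a physicochemical assay for lipophilicity (on this read-out higher numbers stand for higher lipophilicity and lower numbers for lower lipophilicity), compound 1 gives 5.3 and compound 3 gives 5, two numbers within the scatter of each other, so this pair separates on half-life but not on that read-out. Nothing among the data shown accounts for the step in half-life.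

The compounds shown leave open whether the same change would give a step of similar size on the core of compound 2, and where other rings at this place, such as 1,3-oxazol-5-yl, 1,2-thiazol-5-yl or a pyridine, would stand in the Rattus norvegicus assay. A single pair also cannot say whether half-life and partition coefficient go together across this series.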